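Cutting Back the Amide Side Group of Compound 2

A few compounds are considered here, and "the series" means these few. Any claim that something is new, unique, unknown or untested is made for them only; others in the source may bear on it.

Of the compounds shown here, two with a shared core have been measured so far in a physicochemical assay for lipophilicity, at pH 7.4; a higher number here means a more lipophilic compound, a lower number a more polar compound. Compound 1 `CNC(=O)c1cc(C(=O)N[C@H]2[C@@H]3COC[C@@H]32)cc2c1O[C@H](CF)[C@H]2c1ccccc1` gives 3.6, and compound 2 `CNC(=O)c1cc(C(=O)NCCC[C@H]2OC[C@H](N)CO2)cc2c1O[C@H](CF)[C@H]2c1ccccc1` gives 2.9, the lower of the two numbers. The next compound, compound 3 `CNC(=O)c1cc(C(=O)NC)c2c(c1)[C@H](c1ccccc1)[C@@H](CF)O2`, is a cut-back form of compound 2: a hydrogen atom in place of a group of 9 heavy atoms (6 carbon, 1 nitrogen, 2 oxygen; one six-membered non-aromatic ring with 2 hetero atoms), on a saturated chain carbon bound to an amide-type nitrogen.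

Among the measured compounds shown here, only one measured step bears on this change, since it also alters what the same amide-type nitrogen carries. That step, a number 0.70 log units lower from compound 1 to compound 2 (beyond the scatter), swapped one ring-bearing group for a larger one, whereas the new change removes a group and puts nothing of similar size in its place. Compound 3 carries neither group, so the earlier step offers a rough scale but no firm direction. A change no larger than that modest step is expected, most likely a slight rise that stays within the usual scatter. The expected change is small, an estimated a number 0.10 log units higher from compound 2 to compound 3 (within the scatter). For compound 3, the estimated value is 3, with an expected range of 2.5 to 3.5.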

Compound 3, distribution coefficient: 3.3
Compound 3: the middle estimate sits 0.30 log units below what was measured, and the stated range covers the measured number.
By their numbers in this assay, from the lowest: compound 2; then compounds 3 and 1 (each within the scatter of the next).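

In this assay, putting a hydrogen atom in place of the group with the six-membered non-aromatic ring, on a saturated chain carbon bound to an amide-type nitrogen, gives a number 0.40 log units higher from compound 2 to compound 3 (beyond the scatter), so removing this group alone is enough to produce a change beyond the scatter. The other new step, a number 0.30 log units lower from compound 1 to compound 3 (within the scatter), stays within the scatter, which means that one carbon atom and the group of compound 1 cannot be told apart on this amide-type nitrogen, even though that group is much the larger of the two. Among these three compounds, then, only compound 2 stands apart, and size alone does not follow the numbers, although no measurement here says what lies behind this result.

From the compounds shown here alone, these compounds do not separate the ring with its amine from the saturated chain that carries it, so it remains open which part of the group of compound 2 goes with its lower number. Also open, going by these compounds, is how a plain longer chain, or the same chain ending in a carboxylic acid, would read on this amide-type nitrogen in this assay.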